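The source may hold more compounds than are shown below. What is called first, only, known or untested is meant among the compounds shown, and "the series" means these compounds.

Measured compounds in this series:
compound 1, `O=C(O)Cn1c(SCCCNc2ccccc2)nc2ccccc21`: 2690 nM
compound 2, `O=C(O)Cn1c(SCc2ccc(Cl)cc2)nc2ccccc21`: 160 nM

Both were run in an assay on HEK293 cells for displacement of a labelled ligand from prostaglandin D2 receptor 2 (Homo sapiens); on this read-out higher numbers stand for weaker inhibition and lower numbers for stronger inhibition. Compound 1 gives 2690 nM. Compound 2 gives 160 nM, the lowest of the two numbers; the gap to compound 1 lies well beyond the usual scatter of this assay, so compound 2 is the stronger inhibitor of the pair on the present data.

Compound 3, `O=C(O)Cn1c(SCc2ccc(Br)cc2)nc2ccccc21`, has not yet been measured. Against compound 2 the change is bromo in place of chloro on an aromatic carbon. For the measured compounds named here, no pair of measured compounds shows this halogen-for-halogen exchange, so nothing calibrates it; the only measured step, from compound 1 to compound 2, changes a different part of the molecule and does not bear on it. A halogen of one kind is replaced by a halogen of another kind on the same aromatic carbon, with nothing else touched.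

The step from compound 2 to compound 3 is expected to be small, a 1.2-fold lower number from compound 2 to compound 3 (0.09 log units; within the scatter), with a slight lean toward a lower number but within the scatter in either direction. Compound 3 is estimated at 130 nM in this assay, in the range 55 nM to 320 nM.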

Compound 3, half-maximal inhibitory concentration: 220 nM
Beside the measured number, compound 3's estimate is 1.7-fold (0.23 log units) below it; the measured number falls inside the stated range.
By their numbers in this assay, from the lowest: compounds 2 and 3 (each within the scatter of the next); then compound 1.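

In this assay, the change from 4-chlorophenyl to 4-bromophenyl gives a 1.4-fold higher number from compound 2 to compound 3 (0.14 log units; within the scatter) and so leaves the read-out unresolved from the scatter. For the compounds shown here, this aromatic carbon, para to a large group, therefore takes bromo in place of chloro without a change the assay can resolve, which is the first reading of a halogen-for-halogen exchange and one that compound 1 and compound 2 could not supply, since they differ elsewhere. This holds for a single pair at a single position, and nothing available accounts for the two halogens reading alike.

Still open, on these data alone, is how far this tolerance extends on the same aromatic carbon: fluoro, iodo, methyl, methoxy, trifluoromethyl or a plain hydrogen there could each read alike or could separate clearly from chloro and bromo. Also open, as far as these compounds go, is whether the same exchange reads alike with other parts of the molecule changed, for instance with a longer chain in place of the single carbon linking sulfur to the phenyl ring, or with an amide in place of the carboxylic acid.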